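Cyano to methoxy: a step without a starting number

The source may report more compounds than this note shows. Statements on the series, on what has been measured and on what is new or still open speak of the compounds shown alone.

Measured in a functional assay on K562 cells (Homo sapiens) for antiproliferative activity, read by MTT assay, with a stated time of 24 h; a higher number here means a weaker inhibitor, a lower number a stronger inhibitor:
- Compound 1 `COC(=O)c1scc(-c2ccc(NC(=O)c3ccccn3)cc2)c1OC`: 24200 nM
- Compound 2 `COC(=O)c1scc(-c2ccc(NC(=O)c3cc(I)ccc3F)cc2)c1OC`: 35600 nM
- Compound 3 `COC(=O)c1scc(-c2ccc(NC(=O)c3ccc(C#N)nc3)cc2)c1OC`: "not determined" (no result reported)

These compounds share one core and differ in the group on the carbonyl carbon. Compound 3 stands nowhere on the scale, since its entry reads "not determined" (no result reported), so it offers no number to start from.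

Compound 4 `COC(=O)c1scc(-c2ccc(NC(=O)c3ccc(OC)nc3)cc2)c1OC` takes compound 3 and puts methoxy in place of cyano on an aromatic carbon, turning 6-cyanopyridin-3-yl into 6-methoxypyridin-3-yl (methoxy in place of cyano on an aromatic carbon).

Among the compounds with values here, only one measured step bears on this change: a 1.5-fold higher number from compound 1 to compound 2 (0.17 log units; within the scatter). It also swaps the group on a carbonyl carbon, and it stays within the scatter. That is thin evidence, a single pair of compounds, and neither of them carries cyano or methoxy. Still, it gives no reason to expect a shift beyond the scatter from the level that compound 1 and compound 2 share, so the expectation for compound 4 is a value in that same region of this assay. The estimated value for compound 4 is 29000 nM, with an expected range from 12000 nM to 65000 nM.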

Compound 4, half-maximal inhibitory concentration: 18300 nM
Beside the measured number, compound 4's estimate is 1.6-fold (0.20 log units) above it; measured number inside the range.
By their numbers in this assay, from the lowest: compounds 4, 1 and 2 (each within the scatter of the next).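

The change from cyano to methoxy cannot be read as a step, as compound 3 has no number in this assay and compound 4 supplies only the far end of it. What compound 4 does add is a third measured group on the carbonyl carbon, 6-methoxypyridin-3-yl, which carries its methoxy next to the ring nitrogen, and the comparisons with the two earlier groups give a 1.9-fold lower number from compound 2 to compound 4 (0.29 log units; within the scatter) and a 1.3-fold lower number from compound 1 to compound 4 (0.12 log units; within the scatter), so none of the three swaps among compounds 1, 2 and 4 moves the number beyond the scatter. No measurement is available that could explain why these three compounds sit at one level.

As far as these compounds go, whether the 6-cyanopyridin-3-yl group of compound 3 belongs at that same level remains unknown, so the effect of exchanging cyano for methoxy stays open. Also open, from the compounds shown here alone, is whether an amine, a carboxylic acid or a longer chain such as butoxy on that same aromatic carbon would move the number beyond the scatter, in either direction, or leave it at this level.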